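Carbamate ester variation on a fixed core: fluoro for methyl

The compounds below may be only part of what the source reports. "The series", "measured", "known", "first", "only" and "open" are said of these compounds alone.

The series keeps one core and varies the ester side of the carbamate on the piperidine. Compound 1 `Cc1nc(S(C)(=O)=O)ccc1Oc1ncnc(OC2CCN(C(=O)OC(C)C)CC2)c1F` carries an isopropyl ester; in a functional assay on isolated protein for inhibition of Glucose-dependent insulinotropic receptor (Homo sapiens), read by HTRF and cAMP accumulation (on this read-out higher numbers stand for an effect only at larger amounts of compound and lower numbers for an effect already at smaller amounts), compound 1 gives 21 nM. Compound 2 `Cc1nc(S(C)(=O)=O)ccc1Oc1ncnc(OC2CCN(C(=O)OC3CCC3)CC2)c1F` carries a cyclobutyl ester and gives 13.6 nM in this assay; the step of a 1.5-fold lower number from compound 1 to compound 2 (0.19 log units; within the scatter) stays within the scatter. Compound 3 `Cc1nc(S(C)(=O)=O)ccc1Oc1ncnc(OC2CCN(C(=O)OC(C)(C)C#N)CC2)c1F` carries a 1-cyano-1-methylethyl ester and gives 92.9 nM in this assay; the step of a 4.4-fold higher number from compound 1 to compound 3 (0.65 log units; beyond the scatter) goes beyond it, as does a 6.8-fold higher number from compound 2 to compound 3 (0.83 log units; beyond the scatter). Among the three numbers compound 1 thus stands second highest, its nearest neighbour compound 2 within the scatter and compound 3 beyond it.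

Compound 4 `Cc1nc(S(C)(=O)=O)ccc1Oc1ncnc(OC2CCN(C(=O)OC(C)F)CC2)c1F` is the next variation: fluoro in place of methyl on a saturated chain carbon bound to an oxygen next to a carbonyl group and a saturated chain carbon. For the measured compounds named here, no measured step swaps a methyl for a fluoro here. The step from compound 1 to compound 3, a 4.4-fold higher number from compound 1 to compound 3 (0.65 log units; beyond the scatter), is the one that adds a heteroatom substituent on the same ester carbon and gives a modest rise; the step of a 1.5-fold lower number from compound 1 to compound 2 (0.19 log units; within the scatter), an exchange of one hydrocarbon ester for another, gives none beyond the scatter. A rise smaller than that of compound 3 is expected, or none beyond the scatter. The step this estimate means, a 1.7-fold higher number from compound 1 to compound 4 (0.22 log units; within the scatter), is expected to be small. Compound 4 is estimated at 35 nM, with a range from 15 nM to 90 nM.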

Compound 4, half-maximal effective concentration: 65.5 nM
For compound 4 the middle estimate is 1.9-fold (0.27 log units) below the measured one, within the range that was stated.
By their numbers in this assay, from the lowest: compounds 2 and 1 (each within the scatter of the next); then compounds 4 and 3 (each within the scatter of the next).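

Exchanging methyl for fluoro on this saturated chain carbon, isopropyl to 1-fluoroethyl, is not a silent change: a 3.1-fold higher number from compound 1 to compound 4 (0.49 log units; beyond the scatter), although the swap replaces one heavy atom with one heavy atom and leaves the counted hydrogen-bond donors and acceptors unchanged. With a 4.8-fold higher number from compound 2 to compound 4 (0.68 log units; beyond the scatter) also beyond the scatter and a 1.4-fold lower number from compound 3 to compound 4 (0.15 log units; within the scatter) within it, compound 4 and compound 3, which carry fluoro and cyano respectively on that ester carbon, form one group apart from the hydrocarbon esters of compound 1 and compound 2, and none of the four compounds goes against this split. The data available give no explanation for these shifts.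

From the compounds shown here alone, it remains open whether a methoxy or a chloro on the same carbon would give a number like that of compound 4 or that of compound 1, and whether a trifluoromethyl ester would shift the number further. Also open, going by these compounds, is whether a fluoro on the cyclobutyl ester of compound 2 would produce a step of similar size, which would show whether the effect carries over to a ring.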